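A few compounds are considered here, and "the series" means these few. Any claim that something is new, unique, unknown or untested is made for them only; others in the source may bear on it.

Two compounds share one core and differ at a single aromatic carbon. Compound 1 `CSc1ccccc1N1C(N)=NC(N)=NC1(C)C` carries a methylsulfanyl group there, and in an assay for inhibition of Dihydrofolate reductase (Bos taurus), at pH 6.25 (a higher number here means a more potent compound, by a factor of ten per unit of this negative logarithm, a lower number a less potent compound), compound 1 gives 3.54. Compound 2 `CC1(C)N=C(N)N=C(N)N1c1ccccc1F` carries fluoro at the same carbon; in this assay compound 2 gives 4.86, the higher of the two numbers. Among the measured compounds shown here, the only measured step, a number 1.32 log units higher from compound 1 to compound 2 (beyond the scatter), therefore shows a large gain on exchanging methylsulfanyl for fluoro. Compound 3 `CCc1ccccc1N1C(N)=NC(N)=NC1(C)C` is not yet measured; it differs from compound 2 by ethyl in place of fluoro on an aromatic carbon. The counted difference shows ethyl bringing more heavy atoms than the fluoro it replaces, moving back toward the methylsulfanyl of compound 1, which gave 3.54, so a drop from compound 2 is expected, of uncertain size. The expected step is a number 0.66 log units lower from compound 2 to compound 3 (beyond the scatter). Compound 3 is estimated to give 4.2 in this assay, within 3.5 to 4.9.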

Compound 3, logarithm of the reciprocal of the active concentration, log(1/C): 4.02
Compound 3: the middle estimate sits 0.18 log units above what was measured; measured number inside the range.
By their numbers in this assay, from the lowest: compound 1; then compound 3; then compound 2.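

Among the compounds shown here, exchanging fluoro for ethyl in this assay gives a number 0.84 log units lower from compound 2 to compound 3 (beyond the scatter), so methylsulfanyl is no longer the only group seen to stand below fluoro at this aromatic carbon. The exchange of methylsulfanyl for ethyl gives a number 0.48 log units higher from compound 1 to compound 3 (beyond the scatter), which shows that the two groups below fluoro are not interchangeable here. The position therefore separates all three groups, with fluoro giving the highest number, ethyl the middle one and methylsulfanyl the lowest, and the earlier pair alone could not show that intermediate level.

For the compounds shown here, with only three groups compared at this carbon, it remains open where chloro, methoxy or an amine would fall in this order. No supporting measurement on these compounds explains why the three groups differ.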